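A few compounds are considered here, and "the series" means these few. Any claim that something is new, unique, unknown or untested is made for them only; others in the source may bear on it.

Measured in a functional assay on DU-145 cells (Homo sapiens) for inhibition, read by MTT assay, with a stated time of 72 h; a higher number here means a weaker inhibitor, a lower number a stronger inhibitor:
- compound 1 `O=C1C=C(N2CCN(c3ccc(F)cc3)CC2)C(=O)c2ccccc21` gives 11700 nM
- compound 2 `COc1ccc(N2CCN(C3=CC(=O)c4ccccc4C3=O)CC2)cc1` gives 46100 nM
- compound 3 `O=C1C=C(N2CCN(c3cccc(Cl)c3)CC2)C(=O)c2ccccc21` gives 8300 nM

Compound 2 holds the highest number of the three, and its steps to both others lie beyond the scatter. The next compound, compound 4 `COc1ccc(N2CCN(C3=CC(=O)c4ccccc4C3=O)CC2)cc1OC`, differs from it by methoxy in place of hydrogen on an aromatic carbon, ortho to a methoxy group.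

Three measured steps give a sense of scale. The closest is a 3.9-fold higher number from compound 1 to compound 2 (0.60 log units; beyond the scatter), a modest step with methoxy in place of fluoro. The step of a 5.6-fold lower number from compound 2 to compound 3 (0.74 log units; beyond the scatter) is also modest, while a 1.4-fold lower number from compound 1 to compound 3 (0.15 log units; within the scatter) stays within the scatter. As far as these compounds go, none of them adds a second group to the ring, so the direction remains open. Given the modest size of a 3.9-fold higher number from compound 1 to compound 2 (0.60 log units; beyond the scatter), no step beyond the scatter is the central expectation, though a modest step either way remains possible.

The estimate means a 1.2-fold lower number from compound 2 to compound 4 (0.06 log units; within the scatter), an expected step within the scatter. For compound 4 the expected value is 40000 nM, with an estimated range from 16000 nM to 110000 nM in this assay.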

Compound 4, half-maximal inhibitory concentration: 17800 nM
Compound 4: the middle estimate sits 2.2-fold (0.35 log units) above what was measured; measured number inside the range.
By their numbers in this assay, from the lowest: compounds 3, 1 and 4 (each within the scatter of the next, the first and the last beyond it); then compound 2.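

In this assay, methoxy entering ortho to a methoxy group gives a 2.6-fold lower number from compound 2 to compound 4 (0.41 log units; beyond the scatter) and is the first step shown that adds a second group to the ring instead of exchanging one group for another. Among the compounds shown here, this position therefore accepts methoxy, and the added group moves the number down, a direction the earlier steps left open. Nothing available explains this shift, and no measurement bears on its cause.

As far as these compounds go, whether the gain is particular to methoxy remains open, since this single step cannot separate it from a hydroxyl group, an amine or a carboxylic acid at the same place. Also open, from the compounds shown here alone, is whether the same addition would lower the number with fluoro or chloro on the ring in place of the first methoxy group.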